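Sulfonyl substitution on the core: expected effect on cytotoxicity

The source may report more compounds than this note shows. Statements on the series, on what has been measured and on what is new or still open speak of the compounds shown alone.

Measured compounds:
compound 1 `FC(F)(F)c1ccc(-c2nn(-c3ccccc3)cc2-c2nc3ccccc3[nH]2)cc1` — 167000 nM
compound 2 `Cc1ccc(-c2nn(-c3ccccc3)cc2-c2nc3ccccc3n2S(=O)(=O)c2ccc(C)cc2)cc1` — 79300 nM
compound 3 `Cc1ccc(C)c(S(=O)(=O)n2c(-c3cn(-c4ccccc4)nc3-c3ccc(F)cc3)nc3ccccc32)c1` — 54200 nM

In an ADME assay on HEK-293T cells (Homo sapiens) for cytotoxicity, read by MTT assay, with a stated time of 24 h (on this read-out lower numbers stand for higher toxicity in this test and higher numbers for lower toxicity in this test), compound 1 gives 167000 nM, the highest of the three numbers. Compound 2 gives 79300 nM in this assay, a number beyond the scatter below that of compound 1, and compound 3 gives 54200 nM, further below still. Among the measured compounds shown here, no single-point step between measured compounds is available, so these pairs show only their two values; both compounds carrying a sulfonyl group on the ring nitrogen sit lower than the unsubstituted compound 1.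

Compound 4 `O=S(=O)(c1ccc(Br)cc1)n1c(-c2cn(-c3ccccc3)nc2-c2ccc(C(F)(F)F)cc2)nc2ccccc21` is not yet measured. It differs from compound 1 by (4-bromophenyl)sulfonyl in place of hydrogen on an aromatic nitrogen. On the pattern of the two sulfonyl-bearing compounds, a step downward in this assay is expected from compound 1, likely beyond the scatter, a 2.4-fold lower number from compound 1 to compound 4 (0.38 log units; beyond the scatter). The estimate for compound 4 in this assay is 70000 nM, with a range of 30000 nM to 150000 nM.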

Compound 4, half-maximal cytotoxic concentration: 185000 nM
For compound 4 the middle estimate is 2.6-fold (0.42 log units) below the measured one; measured number outside the range, above it.
By their numbers in this assay, from the lowest: compounds 3 and 2 (each within the scatter of the next); then compounds 1 and 4 (each within the scatter of the next).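

In this assay, (4-bromophenyl)sulfonyl in place of hydrogen on the aromatic nitrogen gives a 1.1-fold higher number from compound 1 to compound 4 (0.04 log units; within the scatter), so this large group is accommodated at this position with no readable shift in this test. On the core of compound 1, a sulfonyl group on this nitrogen therefore does not by itself lower the number. Compound 2 and compound 3 differ from compound 1 in more than one place, so their lower numbers cannot be assigned to the sulfonyl group alone. No measurement at hand bears on the reason for this result.

Going by these compounds, it remains open whether other arylsulfonyl groups on the core of compound 1 behave like (4-bromophenyl)sulfonyl. Also open, on these data alone, is whether an acetyl or a short alkyl chain on the same nitrogen, or an amine in place of the bromine, would leave the number in this assay equally unmoved.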